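The source may hold more compounds than are shown below. What is called first, only, known or untested is meant among the compounds shown, and "the series" means these compounds.

Compound 1, with the structure `O=C(O)CNc1cccc(CNc2cc(C(F)(F)F)cc3[nH]ncc23)c1`, is one of two compounds tested in an assay for inhibition of Tryptophan 2,3-dioxygenase (Homo sapiens), with stated times of 10 min and 60 min, tested at 100 uM; a higher number here means a stronger effect of the compound at the concentration tested, a lower number a weaker effect. In this assay compound 1 gives 65%, which is the lower of the two numbers. The other compound, compound 2, has the structure `O=[N+]([O-])c1ccc(Cl)cc1CNc1cc(C(F)(F)F)cc2[nH]ncc12` and in this assay compound 2 gives 88%, a number that lies above that of compound 1 by more than the usual scatter. Compound 3, with the structure `OC1CCCC(Nc2cccc(CNc3cc(C(F)(F)F)cc4[nH]ncc34)c2)C1`, has not yet been measured. It differs from compound 1 in one place: 3-hydroxycyclohexyl in place of carboxymethyl on a nitrogen on an aromatic ring. Among the compounds with values here, no pair of measured compounds shows this kind of change, so nothing measured here tells how large a step to expect. The step from compound 1 to compound 3 in this assay is expected to be small, plausibly none beyond the scatter, as a number 5 percentage points lower from compound 1 to compound 3 (within the scatter). For compound 3 in this assay an inhibition of about 60% is estimated, within a range from 30% to 85%.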

Compound 3, a percentage reported as inhibition, at one concentration (the size of the read-out at that concentration, not a potency): 23%
The estimate for compound 3 lay 37 percentage points above the measured number; measured number outside the range, below it.
By their numbers in this assay, from the lowest: compound 3; then compound 1; then compound 2.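

In this assay, the group on the nitrogen on an aromatic ring clearly matters: putting 3-hydroxycyclohexyl in place of carboxymethyl gives a number 42 percentage points lower from compound 1 to compound 3 (beyond the scatter). The two groups carry the same count of hydrogen-bond donors and acceptors, so those counts alone cannot account for the difference between them, while the six-membered non-aromatic ring of carbon only is new in compound 3. No available measurement explains why this step is so large.

A single change replaces the whole group, so the effect of the ring cannot be separated from the effect of losing the carboxylic acid. A longer carboxylic acid chain such as carboxyethyl, an open-chain alcohol such as hydroxypropyl, or a simple methyl on this nitrogen could help to separate them.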